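The source may hold more compounds than are shown below. What is called first, only, known or untested is meant among the compounds shown, and "the series" means these compounds.

The measured compounds are: compound 1 `COc1cc(-c2cc(/C=C/C(=O)c3ccc(N)cc3)[nH]n2)cc(OC)c1OC` with 91% in a functional assay on MDA-MB-231 cells (Homo sapiens) for cytotoxicity, read by sulforhodamine B assay, with a stated time of 48 h, tested at 0.1 uM; on this read-out lower numbers stand for a stronger effect and higher numbers for a weaker effect at the one concentration tested; compound 2 `COc1ccc(-c2cc(/C=C/C(=O)c3ccc(OC)c(OC)c3)[nH]n2)cc1` with 91%; and compound 3 `COc1ccc(C(=O)/C=C/c2cc(-c3cc(OC)c(OC)c(OC)c3)n[nH]2)cc1` with 94%.

Compound 3 gives the highest of the three numbers, but its step from compound 1 is a number 3 percentage points higher from compound 1 to compound 3 (within the scatter), and its gap to compound 2 is of the same small size, so all three numbers sit together within the scatter. Compound 4 `COc1cc(-c2cc(/C=C/C(=O)c3ccc(F)c(F)c3)[nH]n2)cc(OC)c1OC` differs from compound 3 by 3,4-difluorophenyl in place of 4-methoxyphenyl on a carbonyl carbon. Going by the values given here, no measured step changes this part of the molecule, and the only measured step, a number 3 percentage points higher from compound 1 to compound 3 (within the scatter), stayed within the scatter. A step of a number 1 percentage points lower from compound 3 to compound 4 (within the scatter) is therefore expected, meaning no change beyond the scatter. Compound 4 is estimated at 93%, in a range from 82% to 102%.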

Compound 4, a percentage reported as activity, at one concentration (the size of the read-out at that concentration, not a potency): 96%
Estimate against measurement, compound 4: 3 percentage points below; the measured number falls inside the stated range.
By their numbers in this assay, from the lowest: compounds 1, 2, 3 and 4 (each within the scatter of the next).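

Replacing 4-methoxyphenyl with 3,4-difluorophenyl on the carbonyl carbon gives a number 2 percentage points higher from compound 3 to compound 4 (within the scatter), and replacing 4-aminophenyl with the same group gives a number 5 percentage points higher from compound 1 to compound 4 (within the scatter). In this assay, this position has now carried three different aromatic groups, including one with no hydrogen-bond donor or acceptor, without a change beyond the scatter. Nothing available bears on the reason for this result.

The compounds shown leave open whether a non-aromatic group at this position, such as cyclohexyl, or a ring bearing a carboxylic acid would move the number beyond the scatter.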